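Notes on the aryl-amino change from compound 3 to compound 4

The source may hold more compounds than are shown below. What is called first, only, known or untested is meant among the compounds shown, and "the series" means these compounds.

Measured so far:
compound 1 `O=C(CSc1nc(Nc2ccccc2)c2ccccc2n1)Nc1cccc(Cl)c1`: 14300 nM
compound 2 `O=C(CSc1nc(Nc2ccccc2)c2ccccc2n1)Nc1ccc(Cl)cc1`: 40400 nM
compound 3 `C=CC(=O)Nc1cccc(NC(=O)CSc2nc(Nc3ccccc3Br)c3ccccc3n2)c1`: 12800 nM

All numbers come from a functional assay on MGC-803 cells (Homo sapiens) for inhibition, read by MTT assay, with a stated time of 72 h; a lower number here means a stronger inhibitor, a higher number a weaker inhibitor. Compound 3 holds the lowest number of the three; compound 1 lies within the scatter of it, compound 2 beyond it. Compound 4 `C=CC(=O)Nc1cccc(NC(=O)CSc2nc(Nc3ccc(Cl)c(Cl)c3)c3ccccc3n2)c1` is not yet measured. The change is 3,4-dichlorophenyl in place of 2-bromophenyl on a nitrogen on an aromatic ring. Among the compounds with values here, the only measured step, a 2.8-fold higher number from compound 1 to compound 2 (0.45 log units; beyond the scatter), concerns the chlorophenyl on the amide-type nitrogen, not the group on the nitrogen on an aromatic ring, so it bears on compound 4 only loosely, showing that a single halogen shift can move the number modestly. For compound 4 the expected step is a 1.2-fold lower number from compound 3 to compound 4 (0.07 log units; within the scatter), likely within the scatter in either direction. Compound 4 is therefore estimated at 11000 nM, expected range 4000 nM to 30000 nM.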

Compound 4, half-maximal inhibitory concentration: > 50000 nM
Compound 4 ended at the assay's limit; the forecaster's own chance of this, stated with the estimate: 5%; at least 4.5-fold (0.65 log units) between middle value and limit.
By their numbers in this assay, from the lowest: compounds 3 and 1 (each within the scatter of the next); then compound 2. At a limit, above all of these: compound 4.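

In this assay the group on a nitrogen on an aromatic ring can move the number: 3,4-dichlorophenyl in place of 2-bromophenyl gives an at least 3.9-fold higher number from compound 3 to compound 4 (0.59 log units; beyond the scatter) and so lies beyond the scatter, whereas the earlier step concerned only the amide-type nitrogen. Compound 4 gives > 50000 nM as a limit of the assay and not as a number: the limit of > 50000 nM in this assay, at which 1 of the 4 values shown sits.

The compounds shown do not separate the loss of bromine from the entry of the two chlorines. Also open, as far as these compounds go, is how this nitrogen would fare with 4-chlorophenyl alone, or with a phenyl carrying an amine or a carboxylic acid.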